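The compounds below may be only part of what the source reports. "The series", "measured", "known", "first", "only" and "open" are said of these compounds alone.

Going by the values given here, compound 1, with the structure `COc1ccc(/C=C/C(=O)/C=C/c2ccc(OCc3cn(CCCCOc4cc(=O)oc5ccccc45)nn3)c(OC)c2)cc1OC`, is one of two compounds measured so far in a functional assay on THP-1 cells (Homo sapiens) for inhibition, read by sulforhodamine B assay, with a stated time of 48 h, tested at 50 uM; on this read-out higher numbers stand for more inhibition of growth at the one concentration tested and lower numbers for less inhibition of growth. In this assay compound 1 gives 59%, the higher of the two numbers recorded. The other measured compound, compound 2, has the structure `COc1ccc(/C=C/C(=O)/C=C/c2ccc(OCc3cn(CCCCCOc4cc(=O)oc5ccccc45)nn3)c(OC)c2)cc1OC` and in this assay compound 2 gives 47%, a lower number that lies beyond the usual scatter of repeated measurements. Among the compounds with values here, no single-point step between these two has been worked out, so only their two values can be compared as they stand.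

Compound 3, with the structure `COc1cc(/C=C/C(=O)/C=C/c2cccc3ccccc23)ccc1OCc1cn(CCCCOc2cc(=O)oc3ccccc23)nn1`, has not yet been measured. It differs from compound 1 in one place: naphthalen-1-yl in place of 3,4-dimethoxyphenyl on a double-bonded chain carbon bound to a double-bonded chain carbon. Within the data shown here, with only two measured compounds and no step of this kind recorded, there is little to build on, so the step from compound 1 to compound 3 is expected to be a number 9 percentage points lower from compound 1 to compound 3 (within the scatter), a modest move downward that may well fall within the scatter. On that basis compound 3 is estimated to give 50% in this assay, within a range from 25% to 75%.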

Compound 3, percent growth inhibition at one concentration: 54%
For compound 3 the middle estimate is 4 percentage points below the measured one; the measured number falls inside the stated range.
By their numbers in this assay, from the lowest: compounds 2, 3 and 1 (each within the scatter of the next, the first and the last beyond it).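

In this assay, the exchange of 3,4-dimethoxyphenyl for naphthalen-1-yl on a double-bonded chain carbon bound to a double-bonded chain carbon is a number 5 percentage points lower from compound 1 to compound 3 (within the scatter). This place therefore accepts a second six-membered aromatic ring of carbon only, and the loss of both oxygen atoms and both hydrogen-bond acceptors of the leaving group, with no change in the read-out that can be told from the usual scatter. The pair shows this at one concentration only, and nothing on hand explains why the two groups give such similar numbers.

From the compounds shown here alone, what remains open is whether this tolerance extends to quite different groups at the same place, such as a phenyl ring carrying an amine or a carboxylic acid, or a pyridine ring in place of naphthalen-1-yl. Going by these compounds, it is also open whether compound 1 and compound 3 would still read alike in this assay at other concentrations, since a single test concentration cannot show how the inhibition changes with dose.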